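Chloro to Fluoro on Two Related Biaryl Cores

A few compounds are considered here, and "the series" means these few. Any claim that something is new, unique, unknown or untested is made for them only; others in the source may bear on it.

Compound 2 `COc1ccc(-c2ccn(CCC(C)C)c(=O)c2C#N)cc1Cl` and compound 1 `COc1ccc(-c2ccn(CCC(C)C)c(=O)c2C#N)cc1F` share one core and differ in one place: fluoro in place of chloro on an aromatic carbon. In a functional assay on CHO cells for positive allosteric modulation of metabotropic glutamate receptor 2 (Homo sapiens), read by scintillation counting and GTPgammaS binding, with a stated time of 30 min (on this read-out lower numbers stand for smaller maximal responses and higher numbers for larger maximal responses), compound 2 gives 200%, and in this assay compound 1 gives 160%. The step of a number 40 percentage points lower from compound 2 to compound 1 (beyond the scatter) is the only measured instance of this change among the compounds shown.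

Compound 3 `CCCCn1ccc(-c2ccc(Oc3ccnc(C)c3)c(Cl)c2)c(C#N)c1=O` carries a different core; the difference between the two cores is not broken down here. In this assay compound 3 gives 245%, the highest of the three measured values.

Compound 4 `CCCCn1ccc(-c2ccc(Oc3ccnc(C)c3)c(F)c2)c(C#N)c1=O` has not been measured. It differs from compound 3 by fluoro in place of chloro on an aromatic carbon. This is the same kind of change as that from compound 2 to compound 1, not the same one: there the fluoro sits ortho to a methoxy group, here ortho to a (2-methylpyridin-4-yl)oxy group.

Because a number 40 percentage points lower from compound 2 to compound 1 (beyond the scatter) was measured on the other core, the step of a number 40 percentage points lower from compound 3 to compound 4 (beyond the scatter) is expected to be of similar size. Compound 4 is therefore estimated at 205% in this assay, between 165% and 245%.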

Compound 4, largest response reached (Emax), in percent of the reference or control that the assay uses: 233%
Beside the measured number, compound 4's estimate is 28 percentage points below it; the measured number falls inside the stated range.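

In this assay, the replacement of chloro by fluoro on the second core again lowers the maximal response, giving a number 12 percentage points lower from compound 3 to compound 4 (beyond the scatter). The direction of the change thus carried over from one core to the other, but its size did not: the same change on two cores in this assay, a number 40 percentage points lower (beyond the scatter) from compound 2 to compound 1 and a number 12 percentage points lower (beyond the scatter) from compound 3 to compound 4, 28 percentage points apart, beyond the scatter of two such steps

This does not show what sets the size of the step, as the two cores differ in several places at once and the fluoro stands ortho to a methoxy group in one pair and ortho to a (2-methylpyridin-4-yl)oxy group in the other; two pairs also cannot say how the change would behave on a third core.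

The compounds shown leave open how bromo or an amine would compare with chloro and fluoro on this aromatic carbon. They also leave open whether the step would stay the same with a longer chain on either core, or with the methoxy group swapped for the (2-methylpyridin-4-yl)oxy group on an otherwise unchanged core.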